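From 2-hydroxyphenyl to 4-hydroxyphenyl in one step

The source may hold more compounds than are shown below. What is called first, only, known or untested is meant among the compounds shown, and "the series" means these compounds.

Within the data shown here, in a functional assay on T47D cells (Homo sapiens) for inhibition (a lower number here means a stronger inhibitor, a higher number a weaker inhibitor), compound 2 (`Oc1cccc(-c2cc(-c3cccc(OC(F)(F)F)c3)cc(-c3ccccc3O)n2)c1`) gives 5390 nM, the higher of the two numbers so far, which makes it the weaker inhibitor of the pair. Compound 1 (`Oc1ccc(-c2cc(-c3cccc(C(F)(F)F)c3)cc(-c3cccc(O)c3)n2)cc1`) gives 2630 nM, and that gap lies beyond the usual scatter. Compound 3 (`Oc1ccc(-c2cc(-c3cccc(OC(F)(F)F)c3)cc(-c3cccc(O)c3)n2)cc1`) has the same atoms as compound 2, joined differently: 4-hydroxyphenyl in place of 2-hydroxyphenyl on an aromatic carbon, next to the ring nitrogen (4-hydroxyphenyl in place of 2-hydroxyphenyl on an aromatic carbon). Among the measured compounds shown here, no measured pair isolates this change, so the forecast rests on thin evidence. For the measured compounds named here, the one guide is compound 1, at 2630 nM, which also carries a 4-hydroxyphenyl group. The expected step is a 2.0-fold lower number from compound 2 to compound 3 (0.30 log units; within the scatter), a small move toward stronger inhibition in this assay. The estimate for compound 3 is 2700 nM, with an expected range of 1100 nM to 6500 nM.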

Compound 3, half-maximal inhibitory concentration: 5040 nM
Beside the measured number, compound 3's estimate is 1.9-fold (0.27 log units) below it; the range from low to high includes it.
By their numbers in this assay, from the lowest: compounds 1, 3 and 2 (each within the scatter of the next, the first and the last beyond it).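

Placing 4-hydroxyphenyl in place of 2-hydroxyphenyl on the aromatic carbon next to the ring nitrogen gives a 1.1-fold lower number from compound 2 to compound 3 (0.03 log units; within the scatter) in this assay, so this swap cannot be told apart from repeat-measurement noise. Trifluoromethoxy in place of trifluoromethyl on an aromatic carbon gives a 1.9-fold higher number from compound 1 to compound 3 (0.28 log units; within the scatter), and that change likewise stays inside the noise, so neither single change has a clear effect on the read-out in these pairs. Nothing available here explains either result.

The compounds shown leave open whether this site responds at all to a more different group, such as an amine or a carboxylic acid in place of the hydroxyl. They also leave open whether a longer chain in place of trifluoromethoxy would separate from compound 3.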